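The source may hold more compounds than are shown below. What is called first, only, known or untested is meant among the compounds shown, and "the series" means these compounds.

Compound 1 `Cc1ccc(-c2ccnc(Nc3ccc4c(c3)c(/C=C3/C(=O)Nc5ccccc53)cn4C)n2)cc1` gives > 100000 nM in a functional assay on PA-1 cells (Homo sapiens) for cytotoxicity, read by MTT assay, with a stated time of 48 h (a lower number here means a stronger inhibitor, a higher number a weaker inhibitor), a limit of the assay. Compound 2 `Cn1cc(/C=C2/C(=O)Nc3ccccc32)c2cc(Nc3nccc(-c4ccc(O)cc4)n3)ccc21` gives 9270 nM in this assay. Compound 3 `Cn1cc(/C=C2/C(=O)Nc3ccccc32)c2cc(Nc3nccc(-c4ccc(Cl)cc4Cl)n3)ccc21` gives > 100000 nM in this assay, again only a limit.

Compound 3 thus stands at the limit of > 100000 nM in this assay, at which 2 of the 3 values shown sit, with no number of its own. Compound 4 `Cn1cc(/C=C2/C(=O)Nc3ccccc32)c2cc(Nc3nccc(-c4cccs4)n3)ccc21` differs from it by thiophen-2-yl in place of 2,4-dichlorophenyl on an aromatic carbon. For the measured compounds named here, two measured steps touch this position: an at least 10-fold higher number from compound 2 to compound 3 (1.03 log units; beyond the scatter) and an at least 10-fold lower number from compound 1 to compound 2 (1.03 log units; beyond the scatter), while a step that the two limits leave unreadable from compound 1 to compound 3. Only compound 2, carrying the hydroxy group, gave a number; the other two groups at this position gave limits. Thiophen-2-yl carries no hydroxy group, so compound 4 is expected to give an at least 1.6-fold lower number from compound 3 to compound 4 (0.22 log units; that floor lies within the scatter), most likely a limit again. Compound 4 is estimated at 60000 nM, between 10000 nM and 200000 nM.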

Compound 4, half-maximal inhibitory concentration: 7940 nM
Compound 4: the middle estimate sits 7.6-fold (0.88 log units) above what was measured, outside the stated range (below it).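

A hydroxy group is therefore not required for a measurable value at this position: thiophen-2-yl, which has none, gives an at least 12-fold lower number from compound 3 to compound 4 (1.10 log units; beyond the scatter) and an at least 12-fold lower number from compound 1 to compound 4 (1.10 log units; beyond the scatter). Compared with the hydroxy compound, there is a 1.2-fold lower number from compound 2 to compound 4 (0.07 log units; within the scatter), so in this assay these two groups cannot be told apart. Compound 1 and compound 3 remain at a limit of the assay: the limit of > 100000 nM in this assay, at which 2 of the 4 values shown sit.

The compounds shown leave open whether the smaller ring or its sulfur atom accounts for the difference from compound 3. As far as these compounds go, how a phenyl ring carrying an amine or a carboxylic acid would read also remains open.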